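Shifting the methyl on the phenyl of the triazole substituent

The source may hold more compounds than are shown below. What is called first, only, known or untested is meant among the compounds shown, and "the series" means these compounds.

The series shares one core and varies only the phenyl on the triazole. Compound 1 `CCS[C@@H]1[C@H](SCC)[C@@H](Cn2cc(-c3ccccc3)nn2)O[C@H]1n1ccc(=O)[nH]c1=O` gives 3040 nM in a functional assay on A549 cells (Homo sapiens) for cytotoxicity, read by MTT assay, with a stated time of 72 h; a lower number here means that less compound is needed, a higher number that more compound is needed for the effect. Compound 2 `CCS[C@@H]1[C@H](SCC)[C@@H](Cn2cc(-c3ccc(F)cc3)nn2)O[C@H]1n1ccc(=O)[nH]c1=O` gives 22900 nM there, and compound 3 `CCS[C@@H]1[C@H](SCC)[C@@H](Cn2cc(-c3ccc(C)cc3)nn2)O[C@H]1n1ccc(=O)[nH]c1=O` gives 6780 nM. Compound 3 thus stands second highest of the three numbers: a 2.2-fold higher number from compound 1 to compound 3 (0.35 log units; beyond the scatter) and a 3.4-fold lower number from compound 2 to compound 3 (0.53 log units; beyond the scatter), both modest and both beyond the scatter.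

Compound 4 `CCS[C@@H]1[C@H](SCC)[C@@H](Cn2cc(-c3cccc(C)c3)nn2)O[C@H]1n1ccc(=O)[nH]c1=O` is not yet measured. It differs from compound 3 by 3-methylphenyl in place of 4-methylphenyl on an aromatic carbon. Going by the values given here, no measured step moves a substituent around the phenyl ring in this way; the steps that touch that ring, a 7.5-fold higher number from compound 1 to compound 2 (0.88 log units; beyond the scatter) and a 2.2-fold higher number from compound 1 to compound 3 (0.35 log units; beyond the scatter), replace hydrogen on it and stay modest. The step from compound 3 to compound 4 is therefore expected to be small, likely within the scatter, with no clear direction, so compound 4 is estimated at 6000 nM in this assay, with a range of 2500 nM to 15000 nM, which means an expected step of a 1.1-fold lower number from compound 3 to compound 4 (0.05 log units; within the scatter).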

Compound 4, half-maximal effective concentration: 12200 nM
Compound 4: the middle estimate sits 2.0-fold (0.31 log units) below what was measured, within the range that was stated.
By their numbers in this assay, from the lowest: compound 1; then compounds 3, 4 and 2 (each within the scatter of the next, the first and the last beyond it).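

In this assay, going by these compounds alone, the step of a 1.8-fold higher number from compound 3 to compound 4 (0.26 log units; within the scatter) is the first to move a substituent around the phenyl ring, and it does not separate 3-methylphenyl from 4-methylphenyl at this position. Against 4-fluorophenyl there is no separation either, with a 1.9-fold lower number from compound 2 to compound 4 (0.27 log units; within the scatter) as the printed step, while a 4.0-fold higher number from compound 1 to compound 4 (0.60 log units; beyond the scatter) is the step from the unsubstituted phenyl and lies clear of the scatter. Compounds 2, 3 and 4 thus all give higher numbers than compound 1, and no compound shown goes against this, so both methyl placements share that direction with the fluoro group.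

Going by these compounds, whether an amine, a carboxylic acid or a methoxy group on the same phenyl ring would also raise the number stays open. Nothing at hand gives a cause for these numbers.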